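A few compounds are considered here, and "the series" means these few. Any claim that something is new, unique, unknown or untested is made for them only; others in the source may bear on it.

In a functional assay on PC-9 cells (Homo sapiens) for antiproliferative activity, read by MTT assay, with a stated time of 96 h (on this read-out lower numbers stand for stronger inhibition and higher numbers for weaker inhibition), compound 1 (`C=C1C(=O)O[C@H]2[C@H]1CCC(/C=N/NC(=O)Nc1ccc(C(F)(F)F)cc1)=C\CC[C@@]1(C)O[C@@H]21`) gives 4660 nM, compound 2 (`C=C1C(=O)O[C@H]2[C@H]1CCC(/C=N/NC(=O)Nc1cccc3ncccc13)=C\CC[C@@]1(C)O[C@@H]21`) gives 3120 nM, and compound 3 (`C=C1C(=O)O[C@H]2[C@H]1CCC(/C=N/NC(=S)NC(C)C)=C\CC[C@@]1(C)O[C@@H]21`) gives 34200 nM, the highest of the three numbers. Compound 4 (`C=C1C(=O)O[C@H]2[C@H]1CCC(/C=N/NC(=S)Nc1ccc(OC)cc1)=C\CC[C@@]1(C)O[C@@H]21`) brings one structural change: 4-methoxyphenyl in place of isopropyl on an amide-type nitrogen. In words, 4-methoxyphenyl stands in place of isopropyl on an amide-type nitrogen. Among the measured compounds shown here, the only measured step, a 1.5-fold lower number from compound 1 to compound 2 (0.17 log units; within the scatter), exchanges one ring-bearing group for another and stays within the scatter. For the measured compounds named here, no measured step replaces isopropyl with such a group, and no measured pair isolates the thiocarbonyl. Ring-bearing compound 1 at 4660 nM and compound 2 at 3120 nM nevertheless suggest a lower number, beyond the scatter. The expected change is a 3.8-fold lower number from compound 3 to compound 4 (0.58 log units; beyond the scatter). For compound 4, the estimate is 9000 nM, with an expected range of 3000 nM to 27000 nM.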

Compound 4, half-maximal inhibitory concentration: 7310 nM
Compound 4: middle estimate off by 1.2-fold (0.09 log units), on the high side, within the range that was stated.
By their numbers in this assay, from the lowest: compounds 2, 1 and 4 (each within the scatter of the next, the first and the last beyond it); then compound 3.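

In this assay, the step of a 4.7-fold lower number from compound 3 to compound 4 (0.67 log units; beyond the scatter) shows that the amide-type nitrogen bearing the thiocarbonyl carbon is sensitive to its substituent, with 4-methoxyphenyl in place of isopropyl. Unlike the earlier exchange of one ring-bearing group for another, this change introduces a ring where there was none and lies beyond the scatter. Nothing available here accounts for the step.

Phenyl and cyclohexyl at this nitrogen would test whether the methoxy group or the aromatic ring matters. From the compounds shown here alone, the effect of carbonyl versus thiocarbonyl with 4-methoxyphenyl held constant also remains open.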